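The compounds below may be only part of what the source reports. "The series", "measured", "known", "first", "only" and "open" are said of these compounds alone.

Three compounds built on a shared core have been run in a functional assay on HCC 2998 cells (Homo sapiens) for cytotoxicity, read by sulforhodamine B assay, with a stated time of 48 h, tested at 10 uM; a higher number here means a weaker effect of the compound at the concentration tested, a lower number a stronger effect. In this assay compound 1 `COc1ccc(-c2cc(/C=C/C(=O)c3ccc(OC)c(OC)c3)[nH]n2)cc1` gives -68%, compound 2 `COc1ccc(-c2cc(/C=C/C(=O)c3cc(OC)c(OC)c(OC)c3)[nH]n2)cc1OC` gives -93%, and compound 3 `COc1ccc(C(=O)/C=C/c2cc(-c3cc(OC)c(OC)c(OC)c3)n[nH]2)cc1` gives -83%. Compound 2 holds the lowest of the three numbers, but its gap to compound 3 lies within the scatter, so the two cannot be told apart, whereas its gap to compound 1 lies beyond the scatter. Compound 4 `COc1cc(C(=O)/C=C/c2cc(-c3cc(OC)c(OC)c(OC)c3)n[nH]2)cc(OC)c1OC` has not yet been measured in this assay. It differs from compound 2 by methoxy in place of hydrogen on an aromatic carbon. Within the data shown here, no measured pair shows what this change does, so the expected step is none beyond the scatter. The step expected is a number 3 percentage points higher from compound 2 to compound 4 (within the scatter). Compound 4 is therefore estimated at -90%, with a range from -100% to -75%.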

Compound 4, a percentage reported as activity, at one concentration (the size of the read-out at that concentration, not a potency): -87%
For compound 4 the middle estimate is 3 percentage points below the measured one, and the stated range covers the measured number.
By their numbers in this assay, from the lowest: compounds 2, 4 and 3 (each within the scatter of the next); then compound 1.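

Among these compounds, this is the first pair to show the change of methoxy in place of hydrogen on an aromatic carbon: in this assay it gives a number 6 percentage points higher from compound 2 to compound 4 (within the scatter) and so leaves compound 2 and compound 4 indistinguishable. At this place, ortho to a methoxy group and meta to a large group, the added methoxy is thus tolerated without a readable loss of effect. Nothing available bears on the reason for this result. From the compounds shown here alone, whether a hydroxy group, an amine or a longer alkoxy chain would be tolerated here remains open. So does whether methoxy gives the same result elsewhere on the shared core.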